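Acyl hydrazone in place of methylamide on a shared core

A few compounds are considered here, and "the series" means these few. Any claim that something is new, unique, unknown or untested is made for them only; others in the source may bear on it.

Measured compounds:
Compound 1 `Nc1c(C(=O)NC2CCCC2)oc2nc(-c3ccccc3)cc(C(F)(F)F)c12`: 85000 nM
Compound 2 `CNC(=O)c1oc2nc(-c3ccccc3)cc(C(F)(F)F)c2c1N`: 62000 nM

Both compounds were tested in an ADME assay on HEK293 cells (Homo sapiens) for antiproliferative activity, read by MTT assay; on this read-out lower numbers stand for stronger inhibition and higher numbers for weaker inhibition. Compound 2 holds the lowest of the two numbers, but its nearest neighbour, compound 1, lies within the scatter of it, as the step of a 1.4-fold lower number from compound 1 to compound 2 (0.14 log units; within the scatter) shows. Compound 3 `Cc1ccc(/C=N/NC(=O)c2oc3nc(-c4ccccc4)cc(C(F)(F)F)c3c2N)cc1` differs from compound 2 by a group of 9 heavy atoms (8 carbon, 1 nitrogen; one six-membered aromatic ring of carbon only) in place of one carbon atom, on an amide-type nitrogen. Within the data shown here, the only measured step, that from compound 1 to compound 2, also changes the substituent on this amide-type nitrogen, and it stayed within the scatter. Among the measured compounds shown here, no measured pair covers a group of this size at that place, so the data give no direction for the change. Compound 3 is therefore expected to show a step of a 1.2-fold lower number from compound 2 to compound 3 (0.09 log units; within the scatter), not beyond the scatter. The estimate for compound 3 in this assay is 50000 nM, with a range from 15000 nM to 150000 nM.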

Compound 3, half-maximal inhibitory concentration: 69000 nM
The estimate for compound 3 lay 1.4-fold (0.14 log units) below the measured number; the range from low to high includes it.
By their numbers in this assay, from the lowest: compounds 2, 3 and 1 (each within the scatter of the next).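

In this assay the group of 9 heavy atoms, with its six-membered aromatic ring of carbon only, gives a 1.1-fold higher number from compound 2 to compound 3 (0.05 log units; within the scatter) when it replaces methyl on the amide-type nitrogen and a 1.2-fold lower number from compound 1 to compound 3 (0.09 log units; within the scatter) when it replaces the five-membered non-aromatic ring of carbon. Among these compounds, this place, which had so far carried only those two small groups, thus takes a far larger substituent with a double bond outside aromatic rings, and the read-out still does not separate the three compounds. Nothing available bears on why these numbers stay so close. From the compounds shown here alone, whether a carboxylic acid, an amine or a longer chain on this amide-type nitrogen would give a step beyond the scatter remains open. So does the effect of exchanging the trifluoromethyl on the shared core for a nitrile.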